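Carbamate in place of the amide in the pyrazole series

A few compounds are considered here, and "the series" means these few. Any claim that something is new, unique, unknown or untested is made for them only; others in the source may bear on it.

Measured so far in an assay on CHO-K1 cells for displacement of a labelled ligand from prostaglandin E2 receptor EP1 subtype (Homo sapiens); a lower number here means a stronger inhibitor, a higher number a weaker inhibitor:
compound 1 `Cc1cc(C(=O)Nc2cccc(F)c2)nn1Cc1cc(Cl)ccc1OCc1ccccc1` gives 200 nM
compound 2 `Cc1cc(C(=O)NCc2ccccc2)nn1Cc1cc(Cl)ccc1OCc1ccccc1` gives 39.8 nM
compound 3 `Cc1cc(C(=O)NCc2cccnc2)nn1Cc1cc(Cl)ccc1OCc1ccccc1` gives 50.1 nM

Compound 2 has the lowest number of the three. Its neighbour is compound 3; the step of a 1.3-fold higher number from compound 2 to compound 3 (0.10 log units; within the scatter) lies within the scatter, so the two cannot be ordered. Against compound 1 the step of a 5.0-fold lower number from compound 1 to compound 2 (0.70 log units; beyond the scatter) is clear, as is a 4.0-fold lower number from compound 1 to compound 3 (0.60 log units; beyond the scatter), so a methylene between the amide nitrogen and the aromatic ring goes with a modestly stronger result than the ring set directly on the nitrogen.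

Compound 4 `CCOC(=O)Nc1cc(C)n(Cc2cc(Cl)ccc2OCc2ccccc2)n1` changes compound 2 in one place: (ethoxycarbonyl)amino in place of benzylcarbamoyl on an aromatic carbon. This is not a swap of the group on the amide nitrogen as in the measured steps; the carbonyl-bearing unit itself is replaced, and the six-membered ring that every measured compound carries at this end is gone. Among the measured compounds shown here, no measured pair speaks to this directly. The steps from compound 1 show that what stands at this position moves the number by modest amounts, and the removal of the ring altogether is a larger departure than any of them, so a weaker result is expected for compound 4, with wide uncertainty.

Compound 4 is expected at 250 nM, within 60 nM to 1200 nM. That estimate means a step of a 6.3-fold higher number from compound 2 to compound 4 (0.80 log units; beyond the scatter), expected to run toward a higher number.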

Compound 4, half-maximal inhibitory concentration: 79.4 nM
Compound 4: middle estimate off by 3.1-fold (0.50 log units), on the high side; low and high end bracket the measured number.
By their numbers in this assay, from the lowest: compounds 2, 3 and 4 (each within the scatter of the next); then compound 1.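

In this assay the step of a 2.0-fold higher number from compound 2 to compound 4 (0.30 log units; within the scatter) and the step of a 1.6-fold higher number from compound 3 to compound 4 (0.20 log units; within the scatter) both lie within the scatter, so compound 4 cannot be ordered against compound 2 or compound 3, even though (ethoxycarbonyl)amino has fewer heavy atoms than either group it replaces and no ring. In this small set, the six-membered aromatic ring at this end is therefore not required for a number in the range of the two amides with a saturated carbon on the nitrogen, and a nitrogen rather than a carbonyl can stand on the aromatic carbon. The step of a 2.5-fold lower number from compound 1 to compound 4 (0.40 log units; beyond the scatter) lies beyond the scatter, so the ringless carbamate also reads modestly stronger than the (3-fluorophenyl)carbamoyl group of compound 1.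

No measurement at hand accounts for how well this change is accepted. The compounds shown leave open whether the same range holds with a benzyloxycarbonyl group or a longer alkoxy chain on this nitrogen, or with a urea or a plain amine on the same aromatic carbon.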